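A few compounds are considered here, and "the series" means these few. Any claim that something is new, unique, unknown or untested is made for them only; others in the source may bear on it.

Measured compounds:
Compound 1, `CN1CCN(C[C@H]2CN(c3ccc(-n4cc(-c5ccccn5)cn4)c(F)c3)C(=O)O2)CC1`, gives 1690000 nM in a physicochemical assay for solubility, read by HPLC, with a stated time of 24 h; a higher number here means a more soluble compound, a lower number a less soluble compound.
Compound 2, `O=C1CNC(=O)N1C[C@H]1CN(c2ccc(-n3cc(-c4ccccn4)cn3)c(F)c2)C(=O)O1`, gives 1630000 nM in this assay.
Compound 3, `CCC(=O)NC[C@H]1CN(c2ccc(-n3cc(-c4ccccn4)cn3)c(F)c2)C(=O)O1`, gives 147000 nM in this assay.

Compound 3 stands lowest of the three, with both other compounds well beyond the scatter above it. The relevant steps are an 11-fold lower number from compound 1 to compound 3 (1.06 log units; beyond the scatter) and an 11-fold lower number from compound 2 to compound 3 (1.04 log units; beyond the scatter), both large and both pointing the same way: swapping the group on this saturated chain carbon has so far moved solubility strongly. The unmeasured compound 4, `NC(=O)[C@H]1CN(c2ccc(-n3cc(-c4ccccn4)cn3)c(F)c2)C(=O)O1`, changes the same region of the shared core: carbamoyl in place of (propanoylamino)methyl on a saturated ring carbon. The group that leaves is the one that sits in the least soluble compound, and a smaller group with the same single donor and acceptor enters. Nothing measured shows exactly this carbamoyl, so the expectation is modest: a rise, likely beyond the scatter but short of the values of compounds 1 and 2. The expected step is a 2.7-fold higher number from compound 3 to compound 4 (0.43 log units; beyond the scatter). Compound 4 is therefore estimated at 400000 nM, within a range from 120000 nM to 1300000 nM.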

Compound 4, solubility: 27200 nM
For compound 4 the middle estimate is 15-fold (1.17 log units) above the measured one, and the stated range ends above it.
By their numbers in this assay, from the lowest: compound 4; then compound 3; then compounds 2 and 1 (each within the scatter of the next).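

Carbamoyl on this saturated ring carbon gives the lowest number of the four compounds in this assay (a 5.4-fold lower number from compound 3 to compound 4 (0.73 log units; beyond the scatter)), so the propanoylamino side chain no longer marks the bottom of the series. The gap to the two highest compounds is wider still (a 60-fold lower number from compound 2 to compound 4 (1.78 log units; beyond the scatter); a 62-fold lower number from compound 1 to compound 4 (1.79 log units; beyond the scatter)), and since the groups in compound 3 and compound 4 have the same counts of hydrogen-bond donors and acceptors, those counts alone do not set the number here. Nothing measured on these compounds explains the fall.

The compounds shown leave open whether the fall follows the loss of the chain carbon or the carbamoyl itself. An aminomethyl group or a carboxylic acid on this same ring carbon would help to separate the two.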